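Replacing a bromofluorophenyl with fluorophenyl: expected cell toxicity

The source may report more compounds than this note shows. Statements on the series, on what has been measured and on what is new or still open speak of the compounds shown alone.

Compound 1, `Cc1c(CN2CCN(c3ccc(N4C[C@H](Cn5cc(-c6cncn6C)nn5)OC4=O)cc3F)CC2)cc(-c2ccc(C(C)C)cc2)n1-c1ccc(F)cc1F`, gives > 40000 nM in an ADME assay on J744 cells (Mus musculus) for inhibition, read by MTT assay, with a stated time of 24 h; on this read-out lower numbers stand for stronger inhibition and higher numbers for weaker inhibition; this value is a limit of the assay rather than a number.
Compound 2, `Cc1c(CN2CCN(c3ccc(N4C[C@H](Cn5cc(-c6ccccn6)nn5)OC4=O)cc3F)CC2)cc(-c2ccc(F)cc2F)n1-c1cc(F)ccc1Br`, gives > 40000 nM in this assay; this value is likewise a limit rather than a number.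

Within the data shown here, compound 2 therefore has no exact position on the scale of this assay: it simply sits at the limit of the assay, and the same is true of the one other value shown, since (the limit of > 40000 nM in this assay, at which 2 of the 2 values shown sit). Among the measured compounds shown here, nothing among the measured compounds shows how far either compound lies beyond that limit.

The new compound, compound 3, `Cc1c(CN2CCN(c3ccc(N4C[C@H](Cn5cc(-c6ccccn6)nn5)OC4=O)cc3F)CC2)cc(-c2ccc(F)cc2F)n1-c1ccc(F)cc1`, is reached from compound 2 by a single change: 4-fluorophenyl in place of 2-bromo-5-fluorophenyl on an aromatic nitrogen. The rest of the molecule stays the same.

For the measured compounds named here, with no step between measured compounds available, there is no basis for expecting this change to move the read-out in this assay beyond the usual scatter in either direction; the expectation is that the value stays at the limit. The expected step is a step that the limit leaves unreadable from compound 2 to compound 3. For compound 3 the estimated value in this assay is 50000 nM, within a range from 20000 nM to 150000 nM.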

Compound 3, half-maximal inhibitory concentration: > 40000 nM
Compound 3: a limit, no number; the forecaster's own chance of this, stated with the estimate: 80%; the middle value is on the limit's open side.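

Compound 2 and compound 3 both give a limit of this assay rather than a number, so no step can be read between them: the limit of > 40000 nM in this assay, at which 3 of the 3 values shown sit.

The compounds shown leave open how far each lies beyond that limit, and whether 4-fluorophenyl in place of 2-bromo-5-fluorophenyl changes the read-out at all.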